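The compounds below may be only part of what the source reports. "The series", "measured", "known", "first", "only" and "open" are said of these compounds alone.

Of the compounds shown here, three that share one core have so far been measured in a functional assay on NCI-H1299 cells (Homo sapiens) for inhibition, read by CCK-8 assay, with a stated time of 72 h, tested at 1 uM; a higher number here means more inhibition of growth at the concentration tested, a lower number less inhibition of growth. Compound 1 `CN(C)C(=O)c1cc2cnc(Nc3ccc(NC(=O)C4(C(=O)Nc5ccccc5F)CC4)cc3)nc2n1C1CCCC1` gives 70.2%. Compound 2 `CN(C)C(=O)c1cc2cnc(Nc3ccc(NC(=O)C4(C(=O)Nc5ccc(Cl)c(C(F)(F)F)c5)CC4)cc3)nc2n1C1CCCC1` gives 39.5%, and compound 3 `CN(C)C(=O)c1cc2cnc(Nc3ccc(N)cn3)nc2n1C1CCCC1` gives 60.1%. Of these three numbers compound 2 stands lowest; compound 3 is nearest and compound 1 furthest, each higher by more than the scatter.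

Going by the values given here, only one pair of measured compounds differs in a single place: a number 30.7 percentage points lower from compound 1 to compound 2 (beyond the scatter), where 4-chloro-3-(trifluoromethyl)phenyl replaces 2-fluorophenyl on an amide-type nitrogen.

Compound 4 `CN(C)C(=O)c1cc2cnc(Nc3ccc(NC(=O)C4(C(=O)Nc5ccc(Cl)cc5)CC4)cc3)nc2n1C1CCCC1` has not yet been measured. It differs from compound 2 by hydrogen in place of trifluoromethyl on an aromatic carbon: the trifluoromethyl leaves, and 4-chloro-3-(trifluoromethyl)phenyl becomes 4-chlorophenyl. Among the compounds with values here, that single measured step is the only one bearing on this change, and it was large, but it altered the halogen and added the trifluoromethyl together, so it shows only that the larger aryl group went with a large loss. Taking part of that group away is expected to give back part of the loss. Compound 4 is therefore expected to give 55%, within a range from 35% to 72%. The expected rise is a number 15.5 percentage points higher from compound 2 to compound 4 (beyond the scatter), beyond the scatter but short of a full return.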

Compound 4, percent growth inhibition at one concentration: 52.2%
Compound 4: middle estimate off by 2.8 percentage points, on the high side, within the range that was stated.
By their numbers in this assay, from the lowest: compound 2; then compounds 4 and 3 (each within the scatter of the next); then compound 1.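

In this assay, removing only the trifluoromethyl gives a number 12.7 percentage points higher from compound 2 to compound 4 (beyond the scatter), so this one group, on the aromatic carbon ortho to the chloro group, can now be tied to part of a drop that earlier could be seen only for the whole aryl group. The trifluoromethyl does not account for all of that drop, since 4-chlorophenyl in place of 2-fluorophenyl still gives a number 18 percentage points lower from compound 1 to compound 4 (beyond the scatter), a change that moves the halogen and swaps fluorine for chlorine in one step. No measurement on these compounds explains why growth inhibition shifts in this way.

Still open, going by these compounds, is whether another group on that same aromatic carbon, such as methyl, methoxy or a nitrile, would give a number in this assay closer to that of compound 2 or to that of compound 4. Also open, on these data alone, is how a plain phenyl ring or a 4-fluorophenyl on the amide nitrogen would compare, which could separate what the identity of the halogen contributes from what its place on the ring contributes.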